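A few compounds are considered here, and "the series" means these few. Any claim that something is new, unique, unknown or untested is made for them only; others in the source may bear on it.

Compound 1 `CCN(CC)c1cc2[nH]c(C3CCCCC3)nc2cc1NC(=O)c1cnccn1`: in an ADME assay on Vero cells (Chlorocebus sabaeus) for cytotoxicity, read by resazurin assay, with a stated time of 3 days (on this read-out higher numbers stand for weaker inhibition and lower numbers for stronger inhibition), compound 1 gives only the limit > 100 ug/mL.
Compound 2 `CCN(CC)c1cc2[nH]c(C3CCCCC3)nc2cc1NC(=O)OCC(F)(F)F`: in this assay compound 2 gives only the limit > 100 ug/mL.
Compound 3 `CCCCOC(=O)Nc1cc2nc(C3CCCCC3)[nH]c2cc1N(CC)CC`: in this assay compound 3 gives only the limit > 100 ug/mL.

Compound 3 therefore stands where every measured compound in this series stands, namely at the limit of > 100 ug/mL in this assay, at which 3 of the 3 values shown sit, which is a limit of the assay and not a number. Its position relative to compound 1 and compound 2 cannot be read, and no ordering among the three is possible.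

Compound 4 `CCN(CC)c1cc2[nH]c(C3CCCCC3)nc2cc1NC(=O)c1cccc(Br)c1` is the compound still to be tested in this assay. It differs from compound 3 in a single place: 3-bromophenyl in place of butoxy on a carbonyl carbon. For the measured compounds named here, none of the measured steps involves this change, and none of them carries a readable size: a step that the two limits leave unreadable from compound 1 to compound 2, a step that the two limits leave unreadable from compound 1 to compound 3 and a step that the two limits leave unreadable from compound 2 to compound 3 all run between values that are limits. They bear on compound 4 only in showing that three different groups on the same carbonyl carbon have left the read-out at the limit.

With nothing readable to set a direction, the account expects compound 4 to remain at the limit, estimated at 100 ug/mL with a range from 50 ug/mL to 200 ug/mL. The step expected from this change is a number no higher from compound 3 to compound 4 (the limit leaves the size open), that is, nothing beyond the scatter.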

Compound 4, half-maximal inhibitory concentration: > 100 ug/mL
Compound 4 ended at the assay's limit (the forecaster's own chance of this, stated with the estimate: 80%); the middle value sits exactly at the limit.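

In this assay compound 4 gives > 100 ug/mL, which is a limit of the assay and not a number. No step among compound 1, compound 2, compound 3 and compound 4 can be read, and all four stand at one place: the limit of > 100 ug/mL in this assay, at which 4 of the 4 values shown sit.

The compounds shown leave open how the four truly rank and whether any group on the carbonyl carbon would give a measurable value.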